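Amide variation at the carbonyl of the shared core

The source may report more compounds than this note shows. Statements on the series, on what has been measured and on what is new or still open speak of the compounds shown alone.

Measured so far:
compound 1, `N#CC1(NC(=O)[C@@H]2C[C@@H](S(=O)(=O)c3ccccc3)C[C@H]2C(=O)N2CCS(=O)(=O)CC2)CC1`, gives 4 nM in an assay on isolated protein for inhibition of cathepsin S (Homo sapiens), read by fluorescence, with a stated time of 20 min; on this read-out higher numbers stand for weaker inhibition and lower numbers for stronger inhibition
compound 2, `N#CC1(NC(=O)[C@@H]2C[C@@H](S(=O)(=O)c3ccccc3)C[C@H]2C(=O)N2CCC2)CC1`, gives 10 nM in this assay

Within the data shown here, compound 2 stands at the higher of the two numbers; the only step on record, a 2.5-fold higher number from compound 1 to compound 2 (0.40 log units; beyond the scatter), puts it beyond the scatter from compound 1 and makes it the weaker inhibitor of the pair.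

Compound 3, `CN(C)C(=O)[C@@H]1C[C@H](S(=O)(=O)c2ccccc2)C[C@H]1C(=O)NC1(C#N)CC1`, differs from compound 2 by dimethylamino in place of azetidin-1-yl on a carbonyl carbon. Among the measured compounds shown here, the one measured step concerns the same carbonyl carbon but swaps a much larger cyclic amine for azetidin-1-yl, so it bears on compound 3 only loosely; no measured pair trades azetidin-1-yl for an open-chain amine. With so little to go on, the expected step of a 1.2-fold higher number from compound 2 to compound 3 (0.08 log units; within the scatter) is small and not clearly beyond the scatter. For compound 3 the estimate in this assay is 12 nM, within a range of 5 nM to 30 nM.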

Compound 3, half-maximal inhibitory concentration: 6 nM
Beside the measured number, compound 3's estimate is 2.0-fold (0.30 log units) above it; the range from low to high includes it.
By their numbers in this assay, from the lowest: compounds 1, 3 and 2 (each within the scatter of the next, the first and the last beyond it).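

In this assay, dimethylamino in place of azetidin-1-yl gives a 1.7-fold lower number from compound 2 to compound 3 (0.22 log units; within the scatter), so on this carbonyl carbon the open-chain amine cannot be told apart from the four-membered ring. Dimethylamino in place of 1,1-dioxothiomorpholin-4-yl gives a 1.5-fold higher number from compound 1 to compound 3 (0.18 log units; within the scatter), which places compound 3 within the scatter of both ring-bearing amides, even though those two lie beyond the scatter of each other, so a ring is not required for a value in this range. No available evidence explains these readings.

From the compounds shown here alone, it remains open whether a longer chain such as diethylamino, or a piperidin-1-yl ring, would stay in this range. A secondary amide that keeps the amide hydrogen, such as methylamino on the same carbonyl carbon, is also untested by these compounds.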